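This account rests on a few compounds, and the source may have more. Where it says the series, first, only, none or still open, it means among the compounds named here.

In a functional assay on MCF7 cells (Homo sapiens) for inhibition, read by sulforhodamine B assay (on this read-out higher numbers stand for weaker inhibition of growth and lower numbers for stronger inhibition of growth), the measured set stands as follows:

compound 1 `Cc1ccc2[nH]c(-c3ccc(-c4ccc(-c5cccc(Cl)c5)cc4)cc3)nc2c1` gives 1210 nM
compound 2 `COc1ccc(-c2ccc(-c3ccc(-c4nc5cc(C)ccc5[nH]4)cc3)cc2)cc1OC` gives 190 nM
compound 3 `Oc1cccc2[nH]c(-c3ccc(-c4ccc(-c5cccc(Cl)c5)cc4)cc3)nc12` gives 3420 nM

Compounds 1 and 2 share a core and differ in one place: 3,4-dimethoxyphenyl in place of 3-chlorophenyl on an aromatic carbon. This change gave a 6.4-fold lower number from compound 1 to compound 2 (0.80 log units; beyond the scatter), so within this pair the 3,4-dimethoxyphenyl compound is the stronger inhibitor of growth by a clear margin. Compound 3 carries the highest number of the three in this assay, higher than compound 1 and far higher than compound 2. How the core of compound 3 differs from the core of compound 1 is not broken down here; what the two values show is that compound 3 sits well above compound 1.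

Compound 4 `COc1ccc(-c2ccc(-c3ccc(-c4nc5c(O)cccc5[nH]4)cc3)cc2)cc1OC` is the companion of compound 3 built on the same pattern as compound 2 is to compound 1: 3,4-dimethoxyphenyl in place of 3-chlorophenyl on an aromatic carbon. The change appears twice among the compounds shown, and the words describing the place are the same in both cases, so it is the same change on a different core. Within the data shown here, only one measured instance exists, and nothing beyond that supports carrying it across. The expectation for compound 4 is a step of a 6.3-fold lower number from compound 3 to compound 4 (0.80 log units; beyond the scatter), resting on the step of a 6.4-fold lower number from compound 1 to compound 2 (0.80 log units; beyond the scatter) seen on the related core. Compound 4 is therefore estimated at 540 nM in this assay. The likely range for compound 4 is expected to run from 200 nM to 1500 nM, the width reflecting that the transfer rests on a single prior step.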

Compound 4, concentration for 50% growth inhibition: 190 nM
Compound 4: the middle estimate sits 2.8-fold (0.45 log units) above what was measured; measured number below the stated range.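

In this assay, 3,4-dimethoxyphenyl in place of 3-chlorophenyl lowers the number on the second core as it did on the first, now with an 18-fold lower number from compound 3 to compound 4 (1.26 log units; beyond the scatter), but the size of the step does not carry over as a fixed amount: the same change on two cores in this assay, a 6.4-fold lower number (0.80 log units; beyond the scatter) from compound 1 to compound 2 and an 18-fold lower number (1.26 log units; beyond the scatter) from compound 3 to compound 4, 2.8-fold (0.45 log units) apart, beyond the scatter of two such steps

With 3,4-dimethoxyphenyl present, 4-hydroxy-1H-benzimidazol-2-yl in place of 5-methyl-1H-benzimidazol-2-yl gives no change at the digits printed from compound 2 to compound 4 (within the scatter), whereas with 3-chlorophenyl present, compound 3 stands above compound 1, so the two core changes matter only in the 3-chlorophenyl pair of these four compounds. This shows that the direction held on both cores and that the size depended on the core, but two cores establish no rule for the wider series, and the numbers alone do not explain why the steps differ.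

Still open, going by these compounds, is whether the same direction and a similarly core-dependent size would appear on a third core, and whether both methoxy groups are needed, which a single methoxy group in place of 3-chlorophenyl would test. Also open, on these data alone, is how an amine or a carboxylic acid at that place would behave on these two cores.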